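Amide Replaces Sulfonamide on the Fluorophenyl Side Chain

This account rests on a few compounds, and the source may have more. Where it says the series, first, only, none or still open, it means among the compounds named here.

Compound 3 `O=S(=O)(NCCCNc1nccc(-c2c(-c3cccc(F)c3)nc3sccn23)n1)c1ccccc1` gives 6850 nM in a functional assay on SK-MEL-28 cells (Homo sapiens) for cytotoxicity, read by MTT assay (on this read-out lower numbers stand for stronger inhibition and higher numbers for weaker inhibition), and stands lowest of the two numbers shown. Compound 2 `Cc1ccc(S(=O)(=O)NCCCNc2nccc(-c3c(-c4cccc(F)c4)nc4sccn34)n2)cc1` gives 9500 nM in this assay. For compound 1 `O=S(=O)(NCCCNc1nccc(-c2c(-c3cccc(F)c3)nc3sccn23)n1)c1ccc(F)cc1` this assay reports only a limit, > 20000 nM (the limit of > 20000 nM in this assay, at which 1 of the 3 values shown sits). The step of a 1.4-fold lower number from compound 2 to compound 3 (0.14 log units; within the scatter) lies within the scatter, whereas an at least 2.1-fold lower number from compound 1 to compound 2 (0.32 log units; beyond the scatter) and an at least 2.9-fold lower number from compound 1 to compound 3 (0.46 log units; beyond the scatter) lie beyond it. Compound 4 `O=C(NCCCNc1nccc(-c2c(-c3cccc(F)c3)nc3sccn23)n1)c1ccc(F)cc1` differs from compound 3 by (4-fluorophenyl)carbonyl in place of phenylsulfonyl on an amine nitrogen. Within the data shown here, no measured step covers the sulfonyl-to-carbonyl exchange; the fluoro it brings in is the one compound 1 carries, and an at least 2.9-fold lower number from compound 1 to compound 3 (0.46 log units; beyond the scatter) ran the other way. Compound 4 is therefore expected to show a higher number, about a 2.2-fold higher number from compound 3 to compound 4 (0.34 log units; beyond the scatter). Compound 4 is estimated at 15000 nM, with a range from 5000 nM to 40000 nM.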

Compound 4, half-maximal inhibitory concentration: > 20000 nM
Compound 4: only a limit was reported (the forecaster's own chance of this, stated with the estimate: 40%); middle value at least 1.3-fold (0.12 log units) away from the limit.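

Exchanging the sulfonyl for a carbonyl on this amine nitrogen, with the fluoro added, gives an at least 2.9-fold higher number from compound 3 to compound 4 (0.46 log units; beyond the scatter), and against the methyl analogue it gives an at least 2.1-fold higher number from compound 2 to compound 4 (0.32 log units; beyond the scatter). Compound 4 therefore reports only a limit, so no number marks how far the change goes. With the 4-fluorophenyl group kept, the step between compound 1 and compound 4 cannot be read, because both report only a limit: the limit of > 20000 nM in this assay, at which 2 of the 4 values shown sit.

The compounds shown leave open whether the carbonyl or the fluoro accounts for the rise, which phenylcarbonyl on the same nitrogen would separate. From the compounds shown here alone, how a methoxy group on that ring or a longer chain would read in this assay also stays open.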